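Sec-butoxy to pentyloxy on the shared core

The compounds below may be only part of what the source reports. "The series", "measured", "known", "first", "only" and "open" are said of these compounds alone.

In a functional assay on the whole organism (strain Sprague-Dawley) for inhibition, with Rattus norvegicus as the target, with a stated time of 10 min (on this read-out lower numbers stand for an effect already at smaller amounts and higher numbers for an effect only at larger amounts of compound), compound 1 (`CCOC(=O)c1cnc(-c2ccccc2O)[nH]c1=O`) gives 5 mg/kg and compound 2 (`CCOC(=O)c1cnc(-c2ccccc2OC(C)C)[nH]c1=O`) gives 2 mg/kg while compound 3 (`CCOC(=O)c1cnc(-c2ccccc2OC(C)CC)[nH]c1=O`) gives 0.5 mg/kg as the lowest of the three numbers. Compound 4 (`CCCCCOc1ccccc1-c1ncc(C(=O)OCC)c(=O)[nH]1`) carries pentyl in place of sec-butyl on an oxygen on an aromatic ring. Within the data shown here, two measured steps bear on this change. Isopropyl in place of hydrogen gave a 2.5-fold lower number from compound 1 to compound 2 (0.40 log units; beyond the scatter) and the added methyl gave a 4.0-fold lower number from compound 2 to compound 3 (0.60 log units; beyond the scatter) with both beyond the scatter. Neither step replaces sec-butyl itself, so the trend may not carry over. A small rise is expected, an estimated 1.4-fold higher number from compound 3 to compound 4 (0.15 log units; within the scatter) that stays within the scatter. Compound 4 is expected at 0.7 mg/kg (0.2 mg/kg to 2.5 mg/kg).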

Compound 4, dose for 50% inhibition: 2 mg/kg
For compound 4 the middle estimate is 2.9-fold (0.46 log units) below the measured one; low and high end bracket the measured number.
By their numbers in this assay, from the lowest: compound 3; then compounds 2 and 4 (each within the scatter of the next); then compound 1.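

In this assay, a larger group on this oxygen no longer goes with a lower number: pentyl in place of sec-butyl gives a 4.0-fold higher number from compound 3 to compound 4 (0.60 log units; beyond the scatter). Pentyl in place of isopropyl gives no change at the digits printed from compound 2 to compound 4 (within the scatter), so the added chain length brings no measurable gain over that smaller branched group. Pentyl in place of hydrogen still gives a 2.5-fold lower number from compound 1 to compound 4 (0.40 log units; beyond the scatter). Nothing available explains why sec-butyl and pentyl differ. As far as these compounds go, how a straight butyl chain, a longer chain or an amine at the chain end would read here remains open.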